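The source may report more compounds than this note shows. Statements on the series, on what has been measured and on what is new or still open speak of the compounds shown alone.

Compound 1 `COc1ccc(C2CC(c3ccccc3)=NN2C2=NC(=O)/C(=C3\C(=O)Nc4ccccc43)S2)cc1`: 2010 nM
Compound 2 `COc1ccc(C2CC(c3ccccc3)=NN2C2=NC(=O)/C(=C3\C(=O)Nc4ccc(Br)cc43)S2)cc1`: 180 nM

In a functional assay on cells (Cancer cell lines, Homo sapiens) for cytotoxicity, read by sulforhodamine B assay, with a stated time of 48 h (a lower number here means a stronger inhibitor of growth, a higher number a weaker inhibitor of growth), compound 1 gives 2010 nM, the highest of the two numbers measured. Compound 2, carrying bromo in place of hydrogen on an aromatic carbon, gives 180 nM, and that step, an 11-fold lower number from compound 1 to compound 2 (1.05 log units; beyond the scatter), is the only one known here. Compound 3 `COc1ccc(C2=NN(C3=NC(=O)/C(=C4\C(=O)Nc5ccccc54)S3)C(c3ccc(OC)cc3)C2)cc1` differs from compound 1 by methoxy in place of hydrogen on an aromatic carbon. Among the compounds with values here, no measured step bears directly on this change: the one step known, an 11-fold lower number from compound 1 to compound 2 (1.05 log units; beyond the scatter), alters a different part of the shared core, and nothing in the data tells how the added methoxy acts in this assay. Compound 3 is therefore expected to sit close to compound 1, with no step beyond the scatter, though the range has to stay wide. The estimate for compound 3 in this assay is 2000 nM, from 700 nM to 6000 nM, which means a 1.0-fold lower number from compound 1 to compound 3 (0.00 log units; within the scatter).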

Compound 3, concentration for 50% growth inhibition: 85200 nM
Compound 3: the middle estimate sits 43-fold (1.63 log units) below what was measured, outside the stated range (above it).
By their numbers in this assay, from the lowest: compound 2; then compound 1; then compound 3.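

In this assay, the position para to a large group on this phenyl proves sensitive: going from phenyl to 4-methoxyphenyl gives a 42-fold higher number from compound 1 to compound 3 (1.63 log units; beyond the scatter). This is the first step shown that raises the number, whereas the only earlier step, an 11-fold lower number from compound 1 to compound 2 (1.05 log units; beyond the scatter), lowered it through a change at a different place. Substitution on the shared core can therefore move the number strongly in either direction, depending on the group and where it sits, and nothing available here accounts for the rise seen with methoxy.

As far as these compounds go, it remains open whether a hydroxy, a fluoro or an amine at this same position would raise the number as methoxy does, or whether only methoxy has this effect. Also open, from the compounds shown here alone, is whether bromo would still lower the number on the 4-methoxyphenyl compound 3.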